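This account rests on a few compounds, and the source may have more. Where it says the series, first, only, none or still open, it means among the compounds named here.

Measured so far:
compound 1 `CC1=CC[C@H](C(C)(C)NC(=S)NN)CC1` — 44500 nM
compound 2 `CC1=CC[C@H](C(C)(C)NC(=S)N/N=C/c2ccc(O)cc2)CC1` — 600 nM
compound 3 `CC1=CC[C@H](C(C)(C)NC(=S)N/N=C/c2ccc(N(C)C)cc2)CC1` — limit, see below

In a functional assay on PC-3 cells (Homo sapiens) for inhibition, read by sulforhodamine B assay, with a stated time of 48 h (on this read-out higher numbers stand for weaker inhibition of growth and lower numbers for stronger inhibition of growth), compound 1 gives 44500 nM and compound 2 gives 600 nM. For compound 3 the assay reports only a limit, < 40 nM (the limit of < 40 nM in this assay, at which 1 of the 3 values shown sits). Among the two numbers in this assay, compound 2 stands lowest; the only other number is that of compound 1, a step of an at least 15-fold lower number from compound 2 to compound 3 (1.17 log units; beyond the scatter) does not apply there, and the gap between them lies beyond the scatter.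

Compound 4 `CC1=CC[C@H](C(C)(C)NC(=S)N/N=C/c2ccccc2Cl)CC1` is not yet measured. It differs from compound 2 in one place: 2-chlorophenyl in place of 4-hydroxyphenyl on a carbon with a double bond to nitrogen.

Among the compounds with values here, the one measured step on the same aryl ring is an at least 15-fold lower number from compound 2 to compound 3 (1.17 log units; beyond the scatter), a large change toward a limit. Within the data shown here, that step swaps one substituent for another at the same place; the step to compound 4 instead removes the hydroxy and brings in a chlorine elsewhere on the ring, so no measured step matches it closely. A modest shift in either direction is conceivable; the estimate leans on compound 2 with a wide range.

Compound 4 is expected to give about 500 nM in this assay, between 100 nM and 3000 nM, which would be an expected step of a 1.2-fold lower number from compound 2 to compound 4 (0.08 log units; within the scatter).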

Compound 4, concentration for 50% growth inhibition: 50 nM
Beside the measured number, compound 4's estimate is 10-fold (1.00 log units) above it; the measured number lies below the stated range.
By their numbers in this assay, from the lowest: compound 4; then compound 2; then compound 1. At a limit, below all of these: compound 3.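

In this assay the change to 2-chlorophenyl gives a 12-fold lower number from compound 2 to compound 4 (1.08 log units; beyond the scatter), so a large drop at this place does not depend on the dimethylamino group of compound 3. The entering 2-chlorophenyl counts 0 hydrogen-bond donors and 0 hydrogen-bond acceptors, so the hydroxy of compound 2 is not needed for a number in this range. No measured property in hand accounts for the step.

Compound 3 gives < 40 nM in this assay, which is a limit and not a number, so its order against compound 4 cannot be read. Open, from the compounds shown here alone, is whether the chlorine itself or its place on the ring carries the step; an unsubstituted phenyl, a 4-chlorophenyl or a methoxy group on the ring would separate the two.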